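This account rests on a few compounds, and the source may have more. Where it says the series, first, only, none or still open, it means among the compounds named here.

Compound 1 `CCOC(=O)C1=Cc2ccccc2OC1(OCc1cn(CC(=O)NC2CCCCC2)nn1)C(F)(F)F`: 12100 nM
Compound 2 `CCOC(=O)C1=Cc2ccccc2OC1(OCc1cc(-c2ccc3ccccc3c2)no1)C(F)(F)F`: 65400 nM

Of the compounds shown here, two have so far been tested in a functional assay on MCF7 cells (Homo sapiens) for inhibition, read by MTT assay, with a stated time of 24 h; on this read-out lower numbers stand for stronger inhibition and higher numbers for weaker inhibition. Compound 1 gives 12100 nM, and compound 2 gives 65400 nM. On these two numbers compound 1 stands lowest, and the gap between compound 1 and compound 2 is beyond the usual scatter of such measurements. Among the compounds with values here, the two compounds differ in more than one place, so no single structural step between them is recorded; only their two values can be compared.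

The next compound to be measured is compound 3 `CCOC(=O)C1=Cc2ccccc2OC1(OCc1cn(CC(=O)Nc2ccccc2Br)nn1)C(F)(F)F`. It is built from compound 1 by one change: 2-bromophenyl in place of cyclohexyl on an amide-type nitrogen. The rest of compound 1 is kept unchanged. Within the data shown here, no measured pair in this set carries the same change, so its effect in this assay cannot be read from the numbers at hand. With nothing to go on beyond the value of compound 1 itself, the step of a 1.1-fold lower number from compound 1 to compound 3 (0.04 log units; within the scatter) is expected to stay within the scatter, in neither direction in particular. For compound 3 the estimate in this assay is therefore 11000 nM, with a range from 3000 nM to 40000 nM.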

Compound 3, half-maximal inhibitory concentration: > 150000 nM
Compound 3: no number, only a limit; the forecaster's own chance of this, stated with the estimate: 10%; middle value at least 13-fold (1.13 log units) away from the limit.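

In this assay, putting 2-bromophenyl in place of cyclohexyl on the amide-type nitrogen gives an at least 12-fold higher number from compound 1 to compound 3 (1.09 log units; beyond the scatter), the first sign that inhibition in this set depends on what this nitrogen carries, with the rest of compound 1 kept unchanged. Compound 3 reads > 150000 nM, which is a limit of the assay and not a number. The step therefore fixes only a lower bound on how much weaker inhibition becomes with this change, and its full size cannot be read: the limit of > 150000 nM in this assay, at which 1 of the 3 values shown sits.

The change brings in an aromatic ring and a bromine together, so the compounds shown do not tell which of the two goes with the weaker inhibition, and no cause for the step can be given from them. An unsubstituted phenyl on the same nitrogen would separate the ring from the bromine, while a benzyl or a small alkyl such as methyl would show whether cyclohexyl itself is needed or whether other groups at this place also keep a measurable value.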